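This account rests on a few compounds, and the source may have more. Where it says the series, first, only, none or still open, it means among the compounds named here.

Compounds measured so far:
- compound 1 `CC(C)N1CCN(Cc2csc(N)c2C(=O)c2ccc(Cl)cc2)CC1`: 3.6%
- compound 2 `Nc1scc(CN2CCN(c3ccc(Cl)cc3Cl)CC2)c1C(=O)c1ccc(Cl)cc1`: -11%
- compound 3 `Nc1scc(CN2CCN(c3cc(Cl)cc(Cl)c3)CC2)c1C(=O)c1ccc(Cl)cc1`: -22%

In a functional assay on CHO cells with adenosine receptor A1 (Homo sapiens) as the target, read by cAMP accumulation and immunoassay, with a stated time of 6 min, tested at 0.1 uM (on this read-out higher numbers stand for a weaker effect at the one concentration tested and lower numbers for a stronger effect), compound 3 stands at the lowest of the three numbers; compound 2 is its nearest neighbour and compound 1 its furthest. The step from compound 3 to compound 4 `Nc1scc(CN2CCN(c3ccc(F)cc3Cl)CC2)c1C(=O)c1ccc(Cl)cc1` is 2-chloro-4-fluorophenyl in place of 3,5-dichlorophenyl on an amine nitrogen in a ring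

The measured steps that touch this ring nitrogen are a number 14.6 percentage points lower from compound 1 to compound 2 (beyond the scatter), a number 25.6 percentage points lower from compound 1 to compound 3 (beyond the scatter) and a number 11 percentage points lower from compound 2 to compound 3 (beyond the scatter). The two aryl groups on this nitrogen sat below the isopropyl in both cases, so compound 4, which keeps an aryl group there, is expected to stay in the same region. The pattern of substitution in compound 4 resembles that of compound 2 more than that of compound 3, and the step between those two, a number 11 percentage points lower from compound 2 to compound 3 (beyond the scatter), suggests that swapping back toward a 2,4-pattern may lift the number modestly. Compound 4 is therefore expected to give -12%, within -25% to 2%, a step of a number 10 percentage points higher from compound 3 to compound 4 (within the scatter) that is estimated to be only just beyond the scatter.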

Compound 4, a percentage reported as activity, at one concentration (the size of the read-out at that concentration, not a potency): -6.2%
Compound 4: middle estimate off by 5.8 percentage points, on the low side; low and high end bracket the measured number.
By their numbers in this assay, from the lowest: compound 3; then compounds 2, 4 and 1 (each within the scatter of the next, the first and the last beyond it).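

In this assay, 2-chloro-4-fluorophenyl in place of 3,5-dichlorophenyl on the amine nitrogen gives a number 15.8 percentage points higher from compound 3 to compound 4 (beyond the scatter), so compound 3 stays apart from this further aryl group as well. The first change made on the aryl group itself, fluoro in place of chloro on an aromatic carbon, gives a number 4.8 percentage points higher from compound 2 to compound 4 (within the scatter), so this exchange cannot be told from scatter. Unlike the two dichlorophenyl groups, the 2-chloro-4-fluorophenyl group does not separate from isopropyl, with a number 9.8 percentage points lower from compound 1 to compound 4 (within the scatter), and nothing at hand explains any of these steps.

The groups shown on this nitrogen are only isopropyl and halogenated phenyl rings, so a methoxyphenyl, a benzyl or a 3,5-difluorophenyl group there remains open. Whether fluoro in place of chloro would also leave the number unmoved on the 3,5-dichlorophenyl group is open too.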